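The compounds below may be only part of what the source reports. "The series", "measured", "known", "first", "only" and "open" are said of these compounds alone.

The measured compounds, each with its result in a functional assay on FM3A cells (Mus musculus) for cytotoxicity, read by cell counting, with a stated time of 2 days; on this read-out higher numbers stand for weaker inhibition and lower numbers for stronger inhibition:
compound 1 `Nc1cccc(/C=C2\SC(=O)N(Cc3cccc(Cl)c3)C2=O)c1` gives 164000 nM
compound 2 `Nc1ccc(/C=C2\SC(=O)N(Cc3cccc(Cl)c3)C2=O)cc1` gives 10000 nM
compound 3 `C=C(Br)C(=O)Nc1cccc(/C=C2\SC(=O)N(Cc3ccc(C(C)(C)C)cc3)C2=O)c1` gives 5200 nM

Compound 2 holds the second highest of the three numbers. Its value and that of compound 3 lie within the usual scatter of each other, so no order between these two can be read. Within the data shown here, compound 1 sits far higher; the single step so far, a 16-fold lower number from compound 1 to compound 2 (1.21 log units; beyond the scatter), is the only comparison available, and it concerns the position of the amino group on the shared core, not the halogen on the benzyl ring.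

Compound 4 `Nc1ccc(/C=C2\SC(=O)N(Cc3cccc(F)c3)C2=O)cc1` differs from compound 2 in fluoro in place of chloro on an aromatic carbon. Among the measured compounds shown here, no measured step touches this halogen swap, so nothing in the data points to a change in either direction beyond the scatter. Compound 4 is therefore expected to give about 10000 nM in this assay, with a likely range from 4000 nM to 25000 nM. The estimate amounts to no change at the digits printed from compound 2 to compound 4 (within the scatter), a step expected to stay within the scatter.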

Compound 4, half-maximal inhibitory concentration: 121000 nM
Compound 4: the middle estimate sits 12-fold (1.08 log units) below what was measured, outside the stated range (above it).
By their numbers in this assay, from the lowest: compounds 3 and 2 (each within the scatter of the next); then compounds 4 and 1 (each within the scatter of the next).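

With the 4-aminophenyl core held fixed, the halogen on the benzyl ring proves not to be a silent detail: in this assay the change from 3-chlorophenyl to 3-fluorophenyl gives a 12-fold higher number from compound 2 to compound 4 (1.08 log units; beyond the scatter) and counts as a large step. Among these compounds, until now, the only step read concerned where the amino group sits, so this is the first sign that the far end of the molecule also moves the number, even though one heavy atom replaces another and the counts of hydrogen-bond donors and acceptors stay the same. Nothing at hand explains why this swap has so large an effect.

From the compounds shown here alone, it remains open whether bromo, methyl or methoxy on this aromatic carbon would fall nearer compound 2 or compound 4. Also open, going by these compounds, is whether fluoro in place of chloro would give a step of similar size on the 3-aminophenyl core of compound 1.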